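The compounds below may be only part of what the source reports. "The series", "measured", "known", "first", "only" and "open" are said of these compounds alone.

Of the compounds shown here, three built on one shared core have been tested in a functional assay on A-375 cells (Homo sapiens) for cytotoxicity, read by MTT assay, with a stated time of 72 h; on this read-out higher numbers stand for weaker inhibition and lower numbers for stronger inhibition. Compound 1 `O=C1c2c[n+]([O-])c3ccccc3c2C(=O)c2c1c1ccccc1n2CCCCn1ccnc1` gives 350 nM in this assay. Compound 2 `O=C1c2c[n+]([O-])c3ccccc3c2C(=O)c2c1c1ccccc1n2Cc1cn(CC(O)CO)nn1` gives 440 nM, and a 1.3-fold higher number from compound 1 to compound 2 (0.10 log units; within the scatter). Compound 3 `CCCCN1CCN(CCCCn2c3c(c4ccccc42)C(=O)c2c[n+]([O-])c4ccccc4c2C3=O)CC1` gives 2150 nM, the highest of the three numbers, and a 6.1-fold higher number from compound 1 to compound 3 (0.79 log units; beyond the scatter).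

Compound 4 `CN1CCN(CCCCCCn2c3c(c4ccccc42)C(=O)c2c[n+]([O-])c4ccccc4c2C3=O)CC1` has not yet been measured. Its change from compound 3 is 2-(4-methylpiperazin-1-yl)ethyl in place of 4-butylpiperazin-1-yl on a saturated chain carbon, four bonds along the chain from an aromatic nitrogen. Among the compounds with values here, no measured step matches this change directly. The step of a 6.1-fold higher number from compound 1 to compound 3 (0.79 log units; beyond the scatter) is the only one at a saturated chain carbon four bonds along the chain from an aromatic nitrogen, but there the 4-butylpiperazin-1-yl group arrived, whereas compound 4 keeps a piperazine, so that step sets no direction here. The step of a 1.3-fold higher number from compound 1 to compound 2 (0.10 log units; within the scatter) shows that reshaping the group on a saturated chain carbon bound to an aromatic nitrogen can leave the number within the scatter. Compound 4 is therefore expected to remain near compound 3, with a 1.1-fold lower number from compound 3 to compound 4 (0.03 log units; within the scatter) expected. The estimate for compound 4 is 2000 nM, ranging from 800 nM to 5000 nM.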

Compound 4, half-maximal inhibitory concentration: 630 nM
The estimate for compound 4 lay 3.2-fold (0.50 log units) above the measured number; the measured number lies below the stated range.
By their numbers in this assay, from the lowest: compounds 1, 2 and 4 (each within the scatter of the next); then compound 3.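

In this assay the change keeps a piperazine at this saturated chain carbon, yet it gives a 3.4-fold lower number from compound 3 to compound 4 (0.53 log units; beyond the scatter) and so shows that the number still moves beyond the scatter when the ring stays in place. The piperazine ring therefore does not by itself go with the high number of compound 3, since the remaining steps read a 1.4-fold higher number from compound 2 to compound 4 (0.16 log units; within the scatter) and a 1.8-fold higher number from compound 1 to compound 4 (0.26 log units; within the scatter) and leave compound 4 with the imidazole and triazole compounds. No measured evidence accounts for the drop from compound 3.

The step alters the chain and the outer piperazine substituent together, so the compounds shown do not separate the two, which a 4-methylpiperazin-1-yl group on the shorter chain of compound 3 could do. Going by these compounds, how a morpholine or an unsubstituted piperazine amine would read at this position also remains open.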